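Carboxy for hydroxy on a quinoline-type core: one step, two series

The source may report more compounds than this note shows. Statements on the series, on what has been measured and on what is new or still open speak of the compounds shown alone.

Measured so far:
compound 1, `Cc1c(C(=O)Nc2c(F)cc(-c3cccc(F)c3)cc2F)nc2ccc(C(F)(F)F)cc2c1O`, 9.37%
compound 2, `COc1ccc2nc(C(=O)Nc3ccc(-c4ccccc4)cc3)c(C)c(O)c2c1`, 3.05%
compound 3, `Cc1c(C(=O)Nc2c(F)cc(-c3cccc(F)c3)cc2F)nc2ccc(C(F)(F)F)cc2c1C(=O)O`, 2.56%

Of the compounds shown here, three have been tested in a functional assay on A-375 cells (Homo sapiens) for antiproliferative activity, read by MTT assay, with a stated time of 24 h, tested at 0.14 ug/mL; on this read-out higher numbers stand for a stronger effect at the one concentration tested and lower numbers for a weaker effect. Compound 1 with its structure `Cc1c(C(=O)Nc2c(F)cc(-c3cccc(F)c3)cc2F)nc2ccc(C(F)(F)F)cc2c1O` gives 9.37% in this assay. Compound 3, `Cc1c(C(=O)Nc2c(F)cc(-c3cccc(F)c3)cc2F)nc2ccc(C(F)(F)F)cc2c1C(=O)O`, carries the same core with one change, carboxy in place of hydroxy on an aromatic carbon, and gives 2.56%. The step this change made is a number 6.8 percentage points lower from compound 1 to compound 3 (within the scatter). Compound 2, `COc1ccc2nc(C(=O)Nc3ccc(-c4ccccc4)cc3)c(C)c(O)c2c1`, belongs to a second series; how its core differs from that of compound 1 is not broken down here. In this assay compound 2 gives 3.05%, a number that lies within the scatter of both compound 1 and compound 3.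

Compound 4, `COc1ccc2nc(C(=O)Nc3ccc(-c4ccccc4)cc3)c(C)c(C(=O)O)c2c1`, is not yet measured. It differs from compound 2 by carboxy in place of hydroxy on an aromatic carbon. The place of this change is described in the same words as for the change from compound 1 to compound 3, so the change is the same one, now made on the core of compound 2. Because the earlier change gave a number 6.8 percentage points lower from compound 1 to compound 3 (within the scatter), a step that stayed within the scatter, the step from compound 2 to compound 4 is expected to be small as well, estimated at a number 3.1 percentage points lower from compound 2 to compound 4 (within the scatter). That expectation rests on one earlier pair only. Compound 4 is therefore estimated to give 0% in this assay, with a likely range from -8% to 8%.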

Compound 4, a percentage reported as inhibition, at one concentration (the size of the read-out at that concentration, not a potency): 3.65%
For compound 4 the middle estimate is 3.7 percentage points below the measured one; the measured number falls inside the stated range.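

In this assay, carboxy in place of hydroxy on the aromatic carbon opposite the ring nitrogen gives a number 0.6 percentage points higher from compound 2 to compound 4 (within the scatter), so on the core of compound 2, as on the core of compound 1, the change stays within the scatter. Set side by side, the two steps cannot be told apart, and as far as these two pairs go the change carries from one core to the other without a visible difference: the same change on two cores in this assay, a number 6.8 percentage points lower (within the scatter) from compound 1 to compound 3 and a number 0.6 percentage points higher (within the scatter) from compound 2 to compound 4, 7.4 percentage points apart, within the scatter of two such steps This does not show that the change is without effect in general: there are only two pairs, all four compounds give small numbers at the single concentration tested, and steps this small say nothing about how the change would read on a compound with a much larger effect or at another concentration.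

The compounds shown leave open how other groups on this aromatic carbon would read in this assay, for instance an amine or a nitrile. They also leave open whether the step would stay the same with an ethyl group in place of the methyl group to which this carbon stands ortho.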